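This account rests on a few compounds, and the source may have more. Where it says the series, first, only, none or still open, it means among the compounds named here.

Measured so far in a functional assay on HepG2 cells (Homo sapiens) for inhibition, read by MTT assay, with a stated time of 48 h, tested at 2 uM; on this read-out lower numbers stand for less inhibition and higher numbers for more inhibition at the one concentration tested (going by the name of the read-out):
Compound 1 `Cc1noc(C)c1-c1ccc2c(c1)C(c1ccccc1)NC(=O)N2C`: 32.5%
Compound 2 `Cc1noc(C)c1-c1ccc2c(c1)C(c1ccccc1)N(Cc1nnc(-c3ccccc3)o1)C(=O)N2C`: 34.7%

Of these two numbers compound 2 stands highest, with compound 1 nearest, and that gap lies within the scatter. Compound 3 `Cc1noc(C)c1-c1ccc2c(c1)C(c1ccccc1)N(Cc1ncc(-c3ccccc3)o1)C(=O)N2C` has not yet been measured; it differs from compound 2 by 5-phenyl-1,3-oxazol-2-yl in place of 5-phenyl-1,3,4-oxadiazol-2-yl on a saturated chain carbon bound to an amide-type nitrogen in a ring. Within the data shown here, the one measured step, a number 2.2 percentage points higher from compound 1 to compound 2 (within the scatter), concerns adding the whole group rather than exchanging one five-membered aromatic ring for another, so it bears on this change only loosely, and it was small. Among the measured compounds shown here, no measured step shows the ring exchange itself. The expected step is therefore small: a number 0.7 percentage points lower from compound 2 to compound 3 (within the scatter). Compound 3 is expected to give 34% in this assay, likely between 20% and 50%.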

Compound 3, a percentage reported as inhibition, at one concentration (the size of the read-out at that concentration, not a potency): 50.6%
Compound 3: middle estimate off by 16.6 percentage points, on the low side; the measured number lies above the stated range.
By their numbers in this assay, from the lowest: compounds 1 and 2 (each within the scatter of the next); then compound 3.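

In this assay, among these compounds, 5-phenyl-1,3-oxazol-2-yl in place of 5-phenyl-1,3,4-oxadiazol-2-yl gives a number 15.9 percentage points higher from compound 2 to compound 3 (beyond the scatter), so the make-up of this five-membered aromatic ring matters, although only one ring nitrogen has become carbon. Substitution on the amide-type nitrogen can also shift the read-out: (5-phenyl-1,3-oxazol-2-yl)methyl in place of hydrogen gives a number 18.1 percentage points higher from compound 1 to compound 3 (beyond the scatter), unlike the oxadiazole group. Nothing available explains this difference.

Still open, from the compounds shown here alone, is whether a thiazole ring on the same chain carbon would match the oxazole, and whether an amine on the phenyl ring would change the number.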